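The source may report more compounds than this note shows. Statements on the series, on what has been measured and on what is new or still open speak of the compounds shown alone.

Measured in a functional assay on MCF7 cells (Homo sapiens) for cytotoxicity, read by MTT assay; on this read-out lower numbers stand for stronger inhibition and higher numbers for weaker inhibition:
- compound 1 `COCOc1cc(C#Cc2cc(OC)c(OC)c(OC)c2)ccc1OC` gives 25600 nM
- compound 2 `COCOc1cc(C2CC2c2cc(OC)c(OC)c(OC)c2)ccc1OC` gives 14000 nM
- compound 3 `COc1ccc(C2CC2c2cc(OC)c(OC)c(OC)c2)cc1OP(=O)(O)O` gives 297 nM

Compound 1 and compound 2 lie within the scatter of each other, at the high end of these numbers, while compound 3 shows a much lower number than either.

Next in the series is compound 4 `COc1ccc(C#Cc2cc(OC)c(OC)c(OC)c2)cc1NC(=O)OC(C)(C)C`, which keeps the core of compound 1 and changes one group: (tert-butoxycarbonyl)amino in place of methoxymethoxy on an aromatic carbon. In words, (tert-butoxycarbonyl)amino stands in place of methoxymethoxy on an aromatic carbon.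

Among the compounds with values here, only one measured step touches this place: a 47-fold lower number from compound 2 to compound 3 (1.67 log units; beyond the scatter). Within the data shown here, that step is large, but the group it brings in is a different one, and no measured compound carries (tert-butoxycarbonyl)amino. Its size therefore does not carry over to the present change, and its direction gives only a weak hint. No step beyond the scatter is expected in this assay, with a slight lean towards a lower number.

The expected step is a 1.8-fold lower number from compound 1 to compound 4 (0.26 log units; within the scatter). For compound 4 the estimated value is 14000 nM, with an expected range from 3000 nM to 50000 nM.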

Compound 4, half-maximal inhibitory concentration: > 30000 nM
Compound 4 was reported as a limit (the forecaster's own chance of this, stated with the estimate: 15%); at least 2.1-fold (0.33 log units) between middle value and limit.
By their numbers in this assay, from the lowest: compound 3; then compounds 2 and 1 (each within the scatter of the next). At a limit, above all of these: compound 4.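

In this assay compound 4 gives > 30000 nM, which is a limit of the assay and not a number. From the compounds shown here alone, the measured step is an at least 1.1-fold higher number from compound 1 to compound 4 (0.06 log units; that floor lies within the scatter), so the floor of this change does not separate the two compounds, and the true size of the change from methoxymethoxy to (tert-butoxycarbonyl)amino stays unknown. What is new for this aromatic carbon is that (tert-butoxycarbonyl)amino, a group with a hydrogen-bond donor, gives no lower number on the core of compound 1, although the reading stops at the top of the assay's range: the limit of > 30000 nM in this assay, at which 1 of the 4 values shown sits.

Left open is how a plain amine or a smaller acetylamino group would read on this aromatic carbon, which would show whether the nitrogen or the tert-butyl part of the carbamate goes with the high number. Within the data shown here, also open is whether a phosphate at this place gives a low number on the core of compound 1, as the only large step here, a 47-fold lower number from compound 2 to compound 3 (1.67 log units; beyond the scatter), stands on a different core.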